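The source may hold more compounds than are shown below. What is called first, only, known or untested is meant among the compounds shown, and "the series" means these compounds.

Of the compounds shown here, three sharing one core have been tested in a functional assay on HCT-116 cells (Homo sapiens) for cytotoxicity, read by MTT assay, with a stated time of 72 h; on this read-out lower numbers stand for stronger inhibition and higher numbers for weaker inhibition. Compound 1 `COc1ncc(-c2ccc3nccc(N4CCCC4)c3c2)cc1NS(=O)(=O)c1ccc(F)cc1F` gives 3320 nM. Compound 2 `COc1ncc(-c2ccc3nccc(-c4ccc(C)cc4)c3c2)cc1NS(=O)(=O)c1ccc(F)cc1F` gives 2540 nM, and the step of a 1.3-fold lower number from compound 1 to compound 2 (0.12 log units; within the scatter) changes nothing of note. Compound 3 `CNCCN(C)Cc1ccc(-c2ccnc3ccc(-c4cnc(OC)c(NS(=O)(=O)c5ccc(F)cc5F)c4)cc23)cc1` gives 51.8 nM; among the three it stands lowest, the step of a 49-fold lower number from compound 2 to compound 3 (1.69 log units; beyond the scatter) separating it from its nearest neighbour, with compound 1 further away still. Compound 4 `COc1ncc(-c2ccc3nccc(-c4ccc(CN5CCN(C)CC5)cc4)c3c2)cc1NS(=O)(=O)c1ccc(F)cc1F` has not been measured. It differs from compound 3 by 4-methylpiperazin-1-yl in place of methyl(2-(methylamino)ethyl)amino on a saturated chain carbon bound to an aromatic carbon. Within the data shown here, only the step from compound 2 to compound 3 bears on this change, since both compound 3 and compound 4 carry a nitrogen-containing group on a saturated chain carbon bound to an aromatic carbon; no measured pair shows the open chain against the ring. Because compound 3 already sits at 51.8 nM after the large gain seen in a 49-fold lower number from compound 2 to compound 3 (1.69 log units; beyond the scatter), the expectation for compound 4 is a small step, a 1.5-fold higher number from compound 3 to compound 4 (0.19 log units; within the scatter), close to the scatter. The estimated value for compound 4 in this assay is 80 nM, with a range from 25 nM to 250 nM.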

Compound 4, half-maximal inhibitory concentration: 43.9 nM
Compound 4: the middle estimate sits 1.8-fold (0.26 log units) above what was measured; low and high end bracket the measured number.
By their numbers in this assay, from the lowest: compounds 4 and 3 (each within the scatter of the next); then compounds 2 and 1 (each within the scatter of the next).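

In this assay, replacing the open chain methyl(2-(methylamino)ethyl)amino with the ring 4-methylpiperazin-1-yl gives a 1.2-fold lower number from compound 3 to compound 4 (0.07 log units; within the scatter), so the ring and the chain cannot be told apart here, even though the ring carries 0 hydrogen-bond donors and the chain 1. The large gain at this saturated chain carbon bound to an aromatic carbon is therefore not confined to the open chain: the ring also gives a 58-fold lower number from compound 2 to compound 4 (1.76 log units; beyond the scatter), a step beyond the scatter, as is a 49-fold lower number from compound 2 to compound 3 (1.69 log units; beyond the scatter). No measurement here explains why either group brings this gain.

As far as these compounds go, both groups contain two nitrogens, so it remains open whether a morpholin-4-yl ring or a hydroxyl group on the same carbon would keep the gain. From the compounds shown here alone, the effect of a longer chain carrying the 4-methylpiperazin-1-yl ring also remains open.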